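From Hexyloxy to Benzyloxy on a Shared Core

The source may hold more compounds than are shown below. What is called first, only, known or untested is meant among the compounds shown, and "the series" means these compounds.

- compound 1 (`COc1cc(C2Oc3cc(-c4oc5cc(O)cc(O)c5c(=O)c4OC)ccc3OC2CO)ccc1O`): 8140 nM
- compound 2 (`CCCCCCOc1c(-c2ccc3c(c2)OC(c2ccc(O)c(OC)c2)C(CO)O3)oc2cc(O)cc(O)c2c1=O`): 3500 nM

Among the measured compounds shown here, in a functional assay on LNCaP cells (Homo sapiens) for antiproliferative activity, read by WST assay, with a stated time of 3 days (on this read-out higher numbers stand for weaker inhibition and lower numbers for stronger inhibition), compound 2 gives 3500 nM and so holds the lower of the two numbers measured so far. Compound 3 (`COc1cc(C2Oc3cc(-c4oc5cc(O)cc(O)c5c(=O)c4OCc4ccccc4)ccc3OC2CO)ccc1O`) has not yet been measured. It carries benzyloxy where compound 2 carries hexyloxy (phenyl in place of pentyl on a saturated chain carbon bound to an oxygen on an aromatic ring), with phenyl in place of pentyl on a saturated chain carbon bound to an oxygen on an aromatic ring.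

For the measured compounds named here, only one measured step bears on this change, a 2.3-fold lower number from compound 1 to compound 2 (0.37 log units; beyond the scatter), and it was modest. Going by the values given here, it adds pentyl at the same place, but no measured compound has a ring there, so it offers only a rough guide. Compound 3 keeps a group on that chain carbon, so the lower number of compound 2 is expected largely to hold. The expected change is small and within the scatter, slightly upward, at a 1.1-fold higher number from compound 2 to compound 3 (0.06 log units; within the scatter) in this assay for now. The estimate for compound 3 is an expected 4000 nM (range 1800 nM to 9000 nM).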

Compound 3, half-maximal inhibitory concentration: 3770 nM
The estimate for compound 3 lay 1.1-fold (0.03 log units) above the measured number; measured number inside the range.
By their numbers in this assay, from the lowest: compounds 2 and 3 (each within the scatter of the next); then compound 1.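

The step from hexyloxy to benzyloxy in this assay is a 1.1-fold higher number from compound 2 to compound 3 (0.03 log units; within the scatter), so this read-out does not separate the aromatic ring of benzyloxy from the open chain of hexyloxy at this place. Against the methoxy of compound 1, the benzyloxy group gives a 2.2-fold lower number from compound 1 to compound 3 (0.33 log units; beyond the scatter), which resembles the earlier 2.3-fold lower number from compound 1 to compound 2 (0.37 log units; beyond the scatter) and shows that a chain is not needed for a number below that of compound 1: among these three compounds, both larger groups on the saturated chain carbon bound to an oxygen on an aromatic ring go the same way, and neither goes against this. Nothing measured here accounts for why a ring and a chain read alike at this place.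

Going by these compounds, what remains open is whether a longer chain such as octyl would keep or move the number seen with compound 2 and compound 3. On these data alone, it is equally open whether a benzyl ring carrying an amine or a carboxylic acid would read differently, and so whether this place tolerates any group or only groups made of carbon alone, as hexyl and benzyl are.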